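Swapping a Chloro for a Bromo on the Thiophene Arm

The source may report more compounds than this note shows. Statements on the series, on what has been measured and on what is new or still open speak of the compounds shown alone.

Compounds measured so far:
- compound 1, `C[C@H]1[C@H](NCc2ccc(Cl)s2)C[C@H]2C[C@@H]1C2(C)C`, in an ADME assay on MDCK cells (Canis lupus familiaris) for cytotoxicity, read by microscopy, with a stated time of 48 h (on this read-out lower numbers stand for higher toxicity in this test and higher numbers for lower toxicity in this test), compound 1 gives 25000 nM
- compound 2, `C[C@H]1[C@H](NCc2cccs2)C[C@H]2C[C@@H]1C2(C)C`, compound 2 gives 25000 nM
- compound 3, `CCOc1ccsc1CN[C@@H]1C[C@H]2C[C@@H]([C@H]1C)C2(C)C`, compound 3 gives 50000 nM

Compound 1 stands level with compound 2 at the digits shown, and the two together hold the lowest numbers of the three; compound 3 gives a number that is higher, though the step from compound 2 to compound 3 stays within the scatter of this kind of measurement.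

Compound 4, `C[C@H]1[C@H](NCc2cc(Br)cs2)C[C@H]2C[C@@H]1C2(C)C`, has not yet been measured. It differs from compound 1 in one place: 4-bromothiophen-2-yl in place of 5-chlorothiophen-2-yl on a saturated chain carbon bound to an amine nitrogen.

Among the measured compounds shown here, two measured steps bear on this change. Removing the chloro, no change at the digits printed from compound 1 to compound 2 (within the scatter), moved nothing beyond the scatter. Adding an ethoxy, a 2.0-fold higher number from compound 2 to compound 3 (0.30 log units; within the scatter), also stayed within the scatter. For the measured compounds named here, no measured compound carries a bromo, so nothing in the set speaks directly to that group, but the two changes on the same ring that were measured both left the number essentially where it was.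

For compound 4 the expected outcome in this assay is therefore no step beyond the scatter, no change at the digits printed from compound 1 to compound 4 (within the scatter). The estimated value for compound 4 is 25000 nM, with a range from 12500 nM to 50000 nM.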

Compound 4, minimum cytotoxic concentration: 6250 nM
Estimate against measurement, compound 4: 4.0-fold (0.60 log units) above; measured number below the stated range.
By their numbers in this assay, from the lowest: compound 4; then compounds 1, 2 and 3 (each within the scatter of the next).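

In this assay, among the compounds shown here, the thiophene arm proves not to be indifferent to what it carries: putting a bromo on the unsubstituted arm gives one of the only two steps in the set that lie beyond the scatter (a 4.0-fold lower number from compound 2 to compound 4 (0.60 log units; beyond the scatter)). The comparison with the chloro compound points the same way (a 4.0-fold lower number from compound 1 to compound 4 (0.60 log units; beyond the scatter)), so the 4-bromothiophen-2-yl arm goes with higher toxicity in this test than either the 5-chlorothiophen-2-yl arm or the unsubstituted thiophene arm, whereas removing the chloro left the number unchanged at the digits printed. Nothing measured here explains this shift.

The change from the chloro compound to the bromo compound alters both the halogen and where it sits on the ring, and the compounds shown cannot tell which of the two matters, a question that the 5-bromothiophen-2-yl and 4-chlorothiophen-2-yl arms would help to separate. Also open, from the compounds shown here alone, is whether the shift belongs to bromo itself or would appear with another group in the same place, such as the methyl of a 4-methylthiophen-2-yl arm.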